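The source may hold more compounds than are shown below. What is called first, only, known or untested is meant among the compounds shown, and "the series" means these compounds.

Measured so far in an assay on isolated protein for binding affinity to 5-hydroxytryptamine receptor 1B (Homo sapiens); a lower number here means a stronger inhibitor, a higher number a weaker inhibitor:

- compound 1 `COc1cc2c(cc1N1CCN(C)CC1)N(C(=O)c1ccc(-c3cccc(C)n3)c3ccccc13)CC2` gives 2 nM
- compound 2 `COc1cc2c(cc1N1C[C@@H](C)N[C@@H](C)C1)N(C(=O)c1ccc(-c3ccc(C(C)=O)cc3C)cc1)CC2` gives 3.16 nM
- compound 3 `COc1cc2c(cc1N1C[C@@H](C)N(C)[C@@H](C)C1)N(C(=O)c1ccc(-c3ccccc3C)cc1)CC2` gives 0.631 nM

Compound 1 sits second highest of the three numbers. Its nearest neighbour is compound 2, whose number is within the scatter of that of compound 1, so no order between the two can be read. Compound 3 stands furthest away, with a lower number beyond the scatter.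

Compound 4 `COc1cc2c(cc1N1C[C@@H](C)N[C@@H](C)C1)N(C(=O)c1ccc(-c3cccc(C)n3)c3ccccc13)CC2` is not yet measured. It differs from compound 1 in one place: 3,5-dimethylpiperazin-1-yl in place of 4-methylpiperazin-1-yl on an aromatic carbon. The acyl part of the shared core is unchanged.

Going by the values given here, no measured pair shows this exact change on its own, so the expected size of the step rests on the spread of the three numbers and on the small size of the change. The step of a 1.3-fold higher number from compound 1 to compound 4 (0.10 log units; within the scatter) is expected to stay within the scatter, with no firm direction. Compound 4 is therefore expected to give about 2.5 nM in this assay, with a range from 0.8 nM to 8 nM.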

Compound 4, inhibition constant: 50.1 nM
Compound 4: middle estimate off by 20-fold (1.30 log units), on the low side, outside the stated range (above it).
By their numbers in this assay, from the lowest: compound 3; then compounds 1 and 2 (each within the scatter of the next); then compound 4.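

In this assay, 3,5-dimethylpiperazin-1-yl in place of 4-methylpiperazin-1-yl on the aromatic carbon ortho to a methoxy group gives a 25-fold higher number from compound 1 to compound 4 (1.40 log units; beyond the scatter) and marks this position as sensitive to a small change when the acyl part of compound 1 is held fixed. The entering group carries a hydrogen-bond donor that the leaving group lacks, along with defined stereocentres, and it moves the methyl groups from the ring nitrogen to the ring carbons, all in one step. No measurement available here ties the step to any one of these differences.

The contributions of the lost nitrogen methyl and the added carbon methyls therefore remain unseparated. On this acyl part, an unsubstituted piperazin-1-yl or a 3,4,5-trimethylpiperazin-1-yl group would pull them apart.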